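Amide-to-sulfonamide swap on the threonine nitrogen of the dodecylamide series

A few compounds are considered here, and "the series" means these few. Any claim that something is new, unique, unknown or untested is made for them only; others in the source may bear on it.

Working notes. The series shares a core carrying a saturated chain on one amide and an aromatic acyl group on the amine nitrogen; compound 1 is `CCCCCCCCCCCCNC(=O)[C@@H](NC(=O)c1cccs1)[C@@H](C)O`, compound 2 is `CCCCCCCCCCCCNC(=O)[C@@H](NC(=O)c1cc2ccccc2o1)[C@@H](C)O`, and compound 3 is `CCCCCCCCCCCCNC(=O)[C@@H](NC(=O)c1nccc2ccccc12)[C@@H](C)O`. In a functional assay on SiHa cells (Homo sapiens) for cytotoxicity, read by MTT assay, with a stated time of 48 h (a lower number here means a stronger inhibitor, a higher number a weaker inhibitor), compound 1 gives 23900 nM, which places it second highest of the three numbers. Compound 2 gives 12900 nM and compound 3 gives 56600 nM. The steps among them are a 1.9-fold lower number from compound 1 to compound 2 (0.27 log units; within the scatter), a 2.4-fold higher number from compound 1 to compound 3 (0.37 log units; beyond the scatter) and a 4.4-fold higher number from compound 2 to compound 3 (0.64 log units; beyond the scatter): all measured steps exchange one aromatic ring on the carbonyl carbon for another, and the whole set spans only a modest window.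

Compound 4 is `CCCCCCCCCCCCNC(=O)[C@@H](NS(=O)(=O)c1ccc(C)cc1)[C@@H](C)O`. The change from compound 1 is (4-methylphenyl)sulfonyl in place of (thiophen-2-yl)carbonyl on an amine nitrogen. For the measured compounds named here, none of the measured steps exchanges the carbonyl itself for a sulfonyl, so no step bears directly on this change; the nearest information is that ring exchanges on the carbonyl carbon moved the number only modestly, within a 1.9-fold lower number from compound 1 to compound 2 (0.27 log units; within the scatter) and a 2.4-fold higher number from compound 1 to compound 3 (0.37 log units; beyond the scatter). On that basis the step is expected to be a 1.3-fold higher number from compound 1 to compound 4 (0.10 log units; within the scatter), with no direction confidently beyond the scatter. Compound 4 is therefore estimated at 30000 nM, with a range from 10000 nM to 90000 nM.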

Compound 4, half-maximal inhibitory concentration: 31600 nM
Compound 4: middle estimate off by 1.1-fold (0.02 log units), on the low side, within the range that was stated.
By their numbers in this assay, from the lowest: compounds 2, 1, 4 and 3 (each within the scatter of the next, the first and the last beyond it).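

Working notes on the sulfonyl result. In this assay, for the compounds shown here, the exchange at the amine nitrogen gives a 1.3-fold higher number from compound 1 to compound 4 (0.12 log units; within the scatter) and so stays within the scatter, which shows that this position accepts a sulfonyl in place of the carbonyl without a measurable change in the number; the earlier compounds varied only the ring on a carbonyl carbon. The exchange also replaces the thiophen-2-yl ring with a 4-methylphenyl ring, so this single step cannot separate the contribution of the sulfonyl from that of the ring, and opposing contributions cannot be excluded. No measurement on these groups is available to account for the result.

A (thiophen-2-yl)sulfonyl group on the same nitrogen would separate those two contributions, and a free amine there would test whether an aromatic acyl or sulfonyl group is needed at all. The compounds shown also leave open how the number responds to the saturated chain, as all four carry the dodecyl chain, and an octyl or a hexadecyl chain would address that.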